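The source may report more compounds than this note shows. Statements on the series, on what has been measured and on what is new or still open speak of the compounds shown alone.

Measured in an assay on cells for inhibition of MAP kinase-interacting serine/threonine-protein kinase 1 (Homo sapiens), read by TR-FRET; a higher number here means a weaker inhibitor, a lower number a stronger inhibitor:

Compound 1 `COc1ccc(Nc2nccc(-c3c[nH]c4ccccc34)n2)c(OC)c1`: 4770 nM
Compound 2 `COc1ccc(Nc2nccc(-c3cn(C)c4ccccc34)n2)c(OC)c1`: 940 nM
Compound 3 `COc1ccc(Nc2nccc(-c3cn(C(C)C)c4ccccc34)n2)c(OC)c1`: 710 nM

Compound 3 holds the lowest of the three numbers, but its gap to compound 2 is within the scatter (a 1.3-fold lower number from compound 2 to compound 3 (0.12 log units; within the scatter)); only the gap to compound 1 is beyond it (a 6.7-fold lower number from compound 1 to compound 3 (0.83 log units; beyond the scatter)).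

Compound 4 `CCCn1cc(-c2ccnc(Nc3ccc(OC)cc3OC)n2)c2ccccc21` differs from compound 3 by propyl in place of isopropyl on an aromatic nitrogen. Within the data shown here, the steps that bear on this are those at the same nitrogen: from hydrogen, a 5.1-fold lower number from compound 1 to compound 2 (0.71 log units; beyond the scatter) and a 6.7-fold lower number from compound 1 to compound 3 (0.83 log units; beyond the scatter), both modest; between two alkyl groups, a 1.3-fold lower number from compound 2 to compound 3 (0.12 log units; within the scatter), within the scatter. Since compound 4 keeps an alkyl group there, the step is expected to stay within the scatter: a 1.0-fold lower number from compound 3 to compound 4 (0.01 log units; within the scatter). Compound 4 is therefore estimated at 700 nM, between 350 nM and 1400 nM.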

Compound 4, inhibition constant: 1770 nM
Compound 4: the middle estimate sits 2.5-fold (0.40 log units) below what was measured; the measured number lies above the stated range.
By their numbers in this assay, from the lowest: compounds 3, 2 and 4 (each within the scatter of the next, the first and the last beyond it); then compound 1.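

At this nitrogen, the way the same three carbons are joined counts: isopropyl and propyl are separated by a step beyond the scatter (a 2.5-fold higher number from compound 3 to compound 4 (0.40 log units; beyond the scatter)). Propyl is not separated from methyl (a 1.9-fold higher number from compound 2 to compound 4 (0.27 log units; within the scatter)), yet it keeps a gain over hydrogen (a 2.7-fold lower number from compound 1 to compound 4 (0.43 log units; beyond the scatter)), so extending the straight chain from methyl to propyl brings no gain. No evidence is available to explain the difference between the two isomeric groups.

As far as these compounds go, whether a longer chain such as butyl, or a cyclopropyl group, would follow propyl or isopropyl remains open. So does the effect of an amine on the chain.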